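Sulfonamide chain variation on a shared core

This account rests on a few compounds, and the source may have more. Where it says the series, first, only, none or still open, it means among the compounds named here.

compound 1 `CCCNS(=O)(=O)c1ccc(Nc2ncc3c(n2)N(C2CCCC2)[C@H](CC)C(=O)N3C)cc1`: 2100 nM
compound 2 `CCC1C(=O)N(C)c2cnc(-n3ccc4cc(C(=O)NC)ccc43)nc2N1c1ccn(C)n1`: 35700 nM
compound 3 `CCC1C(=O)N(C)c2cnc(Nc3ccc(S(=O)(=O)NCCCO)cc3)nc2N1c1ccn(C)n1`: 25800 nM

These are the measurements so far in a functional assay on NCI-H1975 cells (Homo sapiens) for antiproliferative activity, read by CCK-8 assay, with a stated time of 72 h; on this read-out higher numbers stand for weaker inhibition of growth and lower numbers for stronger inhibition of growth. Compound 3 stands second highest of the three numbers; its nearest neighbour is compound 2, within the scatter, and its furthest is compound 1, whose number is lower, beyond the scatter. Compound 4 `CCC1C(=O)N(C)c2cnc(Nc3ccc(S(=O)(=O)NCC(C)C)cc3)nc2N1c1ccn(C)n1` differs from compound 3 in a single place: isopropyl in place of 2-hydroxyethyl on a saturated chain carbon bound to a sulfonamide nitrogen. Among the measured compounds shown here, no two measured compounds differ in only one place, so no single step can be read off to guide the change. In this assay a step within the scatter is expected, if anything towards a slightly lower number, as a 1.4-fold lower number from compound 3 to compound 4 (0.16 log units; within the scatter). Compound 4 is therefore estimated at 18000 nM, with a range from 6000 nM to 55000 nM.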

Compound 4, concentration for 50% growth inhibition: 15000 nM
Beside the measured number, compound 4's estimate is 1.2-fold (0.08 log units) above it; the range from low to high includes it.
By their numbers in this assay, from the lowest: compound 1; then compounds 4, 3 and 2 (each within the scatter of the next, the first and the last beyond it).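

Among the compounds shown here, the first single-place step: in this assay isopropyl in place of 2-hydroxyethyl on a saturated chain carbon bound to a sulfonamide nitrogen gives a 1.7-fold lower number from compound 3 to compound 4 (0.24 log units; within the scatter) and so no separation between the two compounds. At this place, the hydrogen-bond donor and acceptor counted for 2-hydroxyethyl can go without the number leaving the scatter. No measurement bears on why the two numbers sit together. Still open, going by these compounds, is whether an amine, a carboxylic acid or a longer chain here would give a step beyond the scatter. Also open, on these data alone, is whether the same change reads alike on the core of compound 1.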